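This account rests on a few compounds, and the source may have more. Where it says the series, first, only, none or still open, it means among the compounds named here.

Measured compounds:
Compound 1, `O=C(Nc1cccc(-c2oc3cc(-c4ccc(F)cc4)ccc3c(=O)c2O)c1)c1ccc(C(F)(F)F)cc1`: in a functional assay on MCF7 cells (Homo sapiens) for antiproliferative activity, read by CCK-8 assay, with a stated time of 72 h (on this read-out lower numbers stand for stronger inhibition and higher numbers for weaker inhibition), compound 1 gives 32600 nM.
Compound 2, `Cc1cc(C(=O)Nc2cccc(-c3oc4cc(-c5ccc(F)cc5)ccc4c(=O)c3O)c2)ccc1F`: in this assay compound 2 gives 7710 nM.

For the measured compounds named here, compound 2 holds the lower of the two numbers so far in this assay, and the only measured step in this set is a 4.2-fold lower number from compound 1 to compound 2 (0.63 log units; beyond the scatter), which separates it from its single neighbour.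

Compound 3, `COc1ccc(C(=O)Nc2cccc(-c3oc4cc(-c5ccc(F)cc5)ccc4c(=O)c3O)c2)c(F)c1`, differs from compound 2 in one place: 2-fluoro-4-methoxyphenyl in place of 4-fluoro-3-methylphenyl on a carbonyl carbon. The measured step of a 4.2-fold lower number from compound 1 to compound 2 (0.63 log units; beyond the scatter) concerns a different pair of groups on the same carbonyl carbon; it shows that exchanging the substituents on this ring can shift the number in this assay by a modest amount, but it does not cover the groups exchanged here and fixes no direction for the new step. Two measured compounds are too few to support any wider pattern. The expectation for compound 3 is therefore a number near that of compound 2, with a step of a 1.3-fold higher number from compound 2 to compound 3 (0.11 log units; within the scatter) expected and the direction uncertain. Compound 3 is estimated at 10000 nM, with a range of 3000 nM to 40000 nM.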

Compound 3, half-maximal inhibitory concentration: 20000 nM
Estimate against measurement, compound 3: 2.0-fold (0.30 log units) below; low and high end bracket the measured number.
By their numbers in this assay, from the lowest: compound 2; then compounds 3 and 1 (each within the scatter of the next).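

In this assay, 2-fluoro-4-methoxyphenyl on the carbonyl carbon in place of 4-fluoro-3-methylphenyl gives (a 2.6-fold higher number from compound 2 to compound 3 (0.41 log units; beyond the scatter)), so compound 2 now stands apart from both other measured compounds by steps beyond the scatter, and 4-fluoro-3-methylphenyl is the best of the three groups at this position for inhibition in this read-out. For the compounds shown here, the second comparison (a 1.6-fold lower number from compound 1 to compound 3 (0.21 log units; within the scatter)) shows that 2-fluoro-4-methoxyphenyl and 4-(trifluoromethyl)phenyl cannot be told apart here, so two differently substituted rings land at the same level and only one group stands out. Nothing available gives a reason for these differences.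

The three compounds exchange more than one substituent on this ring at a time, so they leave open whether the methyl, the methoxy, the trifluoromethyl or the place of the fluorine accounts for the steps. They also leave open how a plain phenyl, a ring carrying an amine or a carboxylic acid, or a pyridine ring would compare with compound 2 at this carbonyl carbon.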